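The source may hold more compounds than are shown below. What is called first, only, known or untested is meant among the compounds shown, and "the series" means these compounds.

In a functional assay on MCF7 cells (Homo sapiens) for cytotoxicity, read by MTT assay, with a stated time of 96 h (a higher number here means a weaker inhibitor, a lower number a stronger inhibitor), compound 1 (`COc1cc(C(=O)c2cn(-c3ccc(F)cc3)cc2-c2ccc([N+](=O)[O-])cc2)cc(OC)c1OC`) gives 240 nM and compound 2 (`COc1cc(C(=O)c2cn(-c3ccc(N)cc3)cc2-c2ccccc2F)cc(OC)c1OC`) gives 28 nM, the lower of the two numbers, with the gap beyond the scatter. Compound 3 (`COc1cc(C(=O)c2cn(-c3ccc(N)cc3)cc2-c2ccc([N+](=O)[O-])cc2)cc(OC)c1OC`) keeps the 4-aminophenyl group of compound 2 and carries 4-nitrophenyl in place of 2-fluorophenyl on an aromatic carbon. For the measured compounds named here, no measured pair isolates this change. Going by the values given here, compound 1, the only measured compound with 4-nitrophenyl, gives 240 nM, so a moderate rise in the number is expected in this assay. The expected step is a 2.1-fold higher number from compound 2 to compound 3 (0.33 log units; beyond the scatter). For compound 3 the estimated value is 60 nM, with an expected range of 15 nM to 240 nM.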

Compound 3, half-maximal inhibitory concentration: 260 nM
Estimate against measurement, compound 3: 4.3-fold (0.64 log units) below, and the stated range ends below it.
By their numbers in this assay, from the lowest: compound 2; then compounds 1 and 3 (each within the scatter of the next).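

In this assay 4-nitrophenyl in place of 2-fluorophenyl gives a 9.3-fold higher number from compound 2 to compound 3 (0.97 log units; beyond the scatter), so with the 4-aminophenyl group held constant, this position two ring bonds from the ring nitrogen responds to the exchange. Amino in place of fluoro on an aromatic carbon gives a 1.1-fold higher number from compound 1 to compound 3 (0.03 log units; within the scatter), so that exchange does not separate the two compounds when 4-nitrophenyl is present. No evidence bears on the cause of either step. Still open, from the compounds shown here alone, is whether the step follows from losing 2-fluorophenyl or from adding 4-nitrophenyl, which unsubstituted phenyl at this position could help separate. Going by these compounds, whether amino and fluoro also stay level alongside 2-fluorophenyl remains open too.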